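The source may hold more compounds than are shown below. What is called first, only, known or untested is meant among the compounds shown, and "the series" means these compounds.

Within the data shown here, compound 2 `CC(C)c1ccc(COc2ccccc2C2CC(=O)c3ccccc3O2)cc1` stands highest of the two numbers measured so far in a functional assay on J774.A1 cells (Mus musculus) for inhibition, read by immunoassay, with a stated time of 12 h, tested at 30 uM (on this read-out lower numbers stand for less inhibition and higher numbers for more inhibition at the one concentration tested (going by the name of the read-out)), giving 91.7%. Compound 1 `CC(C)CCOc1ccccc1C1CC(=O)c2ccccc2O1` gives 43.6% in this assay. Compound 3 `C=CCOc1ccccc1C1CC(=O)c2ccccc2O1` has not yet been measured; it differs from compound 2 in one place: vinyl in place of 4-isopropylphenyl on a saturated chain carbon bound to an oxygen on an aromatic ring. Among the measured compounds shown here, one measured step bears on this change, a number 48.1 percentage points higher from compound 1 to compound 2 (beyond the scatter), where 4-isopropylphenyl replaced isobutyl at the same place. Compound 3 goes the opposite way, from 4-isopropylphenyl to vinyl, so a fall beyond the scatter is expected. Compound 3 is therefore estimated at 40%, within 15% to 70%, meaning a step of a number 51.7 percentage points lower from compound 2 to compound 3 (beyond the scatter).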

Compound 3, a percentage reported as inhibition, at one concentration (the size of the read-out at that concentration, not a potency): 47%
Compound 3: the middle estimate sits 7 percentage points below what was measured, and the stated range covers the measured number.
By their numbers in this assay, from the lowest: compounds 1 and 3 (each within the scatter of the next); then compound 2.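

In this assay, vinyl and isobutyl at this place read alike, with a number 3.4 percentage points higher from compound 1 to compound 3 (within the scatter), so the double bond that vinyl brings makes no change beyond the scatter here. The 4-isopropylphenyl group stands apart, with a number 44.7 percentage points lower from compound 2 to compound 3 (beyond the scatter), and among these three compounds only the group holding an aromatic ring gives the high number. Nothing given here explains this gap. On these data alone, it stays open whether the ring alone is enough or its isopropyl group is also needed, as a plain phenyl or a phenyl bearing a carboxylic acid at this place would show.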